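A few compounds are considered here, and "the series" means these few. Any claim that something is new, unique, unknown or untested is made for them only; others in the source may bear on it.

Of the compounds shown here, three sharing one core have been tested in a functional assay on XF498 cells (Homo sapiens) for antiproliferative activity, read by MTT assay, with a stated time of 96 h; a lower number here means a stronger inhibitor, a higher number a weaker inhibitor. Compound 1 `CN(C)c1ccc(N2C(=O)NC3(CSC4=C3C(=O)c3ncccc3C4=O)C2=O)cc1` gives 800 nM, compound 2 `CCCc1ccc(N2C(=O)NC3(CSC4=C3C(=O)c3ncccc3C4=O)C2=O)cc1` gives 450 nM, and compound 3 `O=C1C2=C(C(=O)c3ncccc31)C1(CS2)NC(=O)N(c2ccc(Cl)cc2)C1=O` gives 590 nM; compound 3 stands within the scatter of both others, so none of the three can be separated. Compound 4 `O=C1C2=C(C(=O)c3ncccc31)C1(CS2)NC(=O)N(c2ccc([N+](=O)[O-])cc2)C1=O` differs from compound 3 by nitro in place of chloro on an aromatic carbon. The earlier changes at this same aromatic carbon, a 1.4-fold lower number from compound 1 to compound 3 (0.13 log units; within the scatter) and a 1.3-fold higher number from compound 2 to compound 3 (0.12 log units; within the scatter), as well as a 1.8-fold lower number from compound 1 to compound 2 (0.25 log units; within the scatter), all stayed within the scatter, so exchanging one group for another at this place has not yet moved the numbers. For compound 4 a step within the scatter is therefore expected in this assay, a 1.1-fold lower number from compound 3 to compound 4 (0.03 log units; within the scatter). Compound 4 is estimated at 550 nM, between 250 nM and 1200 nM.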

Compound 4, half-maximal inhibitory concentration: 1030 nM
Compound 4: middle estimate off by 1.9-fold (0.27 log units), on the low side, within the range that was stated.
By their numbers in this assay, from the lowest: compounds 2, 3, 1 and 4 (each within the scatter of the next, the first and the last beyond it).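

Within the data shown here, the nitro group gives the first step at this aromatic carbon that leaves the scatter: a 2.3-fold higher number from compound 2 to compound 4 (0.36 log units; beyond the scatter) is modest, but it shows that exchanging groups here can change the number. The other two steps, a 1.7-fold higher number from compound 3 to compound 4 (0.24 log units; within the scatter) and a 1.3-fold higher number from compound 1 to compound 4 (0.11 log units; within the scatter), stay within the scatter, so compound 4 separates only from compound 2. No evidence available here bears on this result.

On these data alone, whether an amine, a carboxylic acid or a longer chain at this carbon would widen the gap remains open. So does whether the same order holds in other cell lines.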